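A few compounds are considered here, and "the series" means these few. Any claim that something is new, unique, unknown or untested is made for them only; others in the source may bear on it.

For the measured compounds named here, compound 2 `CC1(C)CC(OC(=O)CN2CN(c3ccccc3)C3(CCN(C(=O)c4ccc(C(C)(C)C)cc4)CC3)C2=O)CC(C)(C)N1` gives 1300 nM in an assay on HEK293 cells for displacement of a labelled ligand from NPC1-like intracellular cholesterol transporter 1 (Homo sapiens) (a lower number here means a stronger inhibitor, a higher number a weaker inhibitor), the lowest of the two numbers so far. Compound 1 `CC1CCCN(C(=O)CN2CN(c3ccccc3)C3(CCN(C(=O)c4ccc(C(C)(C)C)cc4)CC3)C2=O)C1` gives 12000 nM. Compound 3 `CC(C)(C)c1ccc(C(=O)N2CCC3(CC2)C(=O)N(CC(=O)N2CCCC(CO)C2)CN3c2ccccc2)cc1` carries 3-(hydroxymethyl)piperidin-1-yl in place of (2,2,6,6-tetramethylpiperidin-4-yl)oxy on a carbonyl carbon. Going by the values given here, the only step that bears on this is a 9.2-fold lower number from compound 1 to compound 2 (0.97 log units; beyond the scatter), in which the same position moved from an amide with 3-methylpiperidin-1-yl to the ester; compound 3 returns to an amide, now with 3-(hydroxymethyl)piperidin-1-yl, so most of that gain is expected to be lost. The step from compound 2 to compound 3 is estimated at a 4.6-fold higher number from compound 2 to compound 3 (0.66 log units; beyond the scatter). Compound 3 is thus expected near 6000 nM, within 2000 nM to 20000 nM.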

Compound 3, half-maximal inhibitory concentration: 8200 nM
Beside the measured number, compound 3's estimate is 1.4-fold (0.14 log units) below it; measured number inside the range.
By their numbers in this assay, from the lowest: compound 2; then compounds 3 and 1 (each within the scatter of the next).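

In this assay, 3-(hydroxymethyl)piperidin-1-yl in place of (2,2,6,6-tetramethylpiperidin-4-yl)oxy on a carbonyl carbon gives a 6.3-fold higher number from compound 2 to compound 3 (0.80 log units; beyond the scatter), so a second amide also falls short of the ester in compound 2. Hydroxy in place of hydrogen on the saturated chain carbon gives a 1.5-fold lower number from compound 1 to compound 3 (0.17 log units; within the scatter), so this change does not separate the two amides. Nothing available bears on why the ester stands apart.

As far as these compounds go, it remains open whether the ester link or the tetramethylpiperidine ring carries the difference. An amide with a 2,2,6,6-tetramethylpiperidin-4-ylamino group would separate the two.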